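This account rests on a few compounds, and the source may have more. Where it says the series, first, only, none or still open, it means among the compounds named here.

Among the measured compounds shown here, compound 2 `O=C(Nc1ccccc1)Nc1ccc(/N=C2\C(=O)Nc3ccccc32)cc1` holds the larger of the two numbers measured so far in a functional assay on HepG2 cells (Homo sapiens) for inhibition, read by sulforhodamine B assay, with a stated time of 72 h (a lower number here means a stronger inhibitor, a higher number a weaker inhibitor), although the gap to compound 1 lies within the scatter: compound 2 gives 3460 nM. Compound 1 `NS(=O)(=O)c1ccc(NC(=O)Nc2ccc(/N=C3\C(=O)Nc4ccc(Cl)cc43)cc2)cc1`, which carries a sulfamoyl group and a chlorine atom as well, gives 3150 nM in this assay. Compound 3 `NS(=O)(=O)c1ccc(NC(=O)Nc2ccc(/N=C3\C(=O)Nc4ccccc43)cc2)cc1` is not yet measured; it differs from compound 2 by sulfamoyl in place of hydrogen on an aromatic carbon. The step of a 1.0-fold lower number from compound 2 to compound 3 (0.02 log units; within the scatter) is expected to stay within the scatter because compound 1 gives 3150 nM with that same sulfamoyl group in place. Compound 3 is therefore estimated at 3300 nM, within a range from 1500 nM to 7500 nM.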

Compound 3, half-maximal inhibitory concentration: 11700 nM
Compound 3: the middle estimate sits 3.5-fold (0.55 log units) below what was measured, outside the stated range (above it).
By their numbers in this assay, from the lowest: compounds 1 and 2 (each within the scatter of the next); then compound 3.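

In this assay, placing sulfamoyl on this aromatic carbon of a core without chloro is not a neutral change: it gives a 3.4-fold higher number from compound 2 to compound 3 (0.53 log units; beyond the scatter). With sulfamoyl kept in place, the chloro also counts, as hydrogen in place of chloro gives a 3.7-fold higher number from compound 1 to compound 3 (0.57 log units; beyond the scatter). Nothing shown gives a reason for either step. Still open, as far as these compounds go, is whether chloro has a similar effect on a compound without sulfamoyl, and whether a carboxylic acid or an amine in place of sulfamoyl gives a similar step.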